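The source may report more compounds than this note shows. Statements on the series, on what has been measured and on what is new or still open speak of the compounds shown alone.

Compound 1 `CC(C)(C)OC(=O)NC1CCCN(C(=O)CN2CN(c3ccccc3)C3(CCN(C(=O)c4ccc(C5CCCCC5)cc4)CC3)C2=O)C1`, compound 2 `CC(C)(C)c1ccc(C(=O)N2CCC3(CC2)C(=O)N(CC(=O)N2CCNCC2)CN3c2ccccc2)cc1` and compound 3 `COC(=O)CCCNC(=O)CN1CN(c2ccccc2)C2(CCN(C(=O)c3ccc(C4CCCCC4)cc3)CC2)C1=O` share one core and differ in the groups attached to it. In an assay on HEK293 cells for displacement of a labelled ligand from NPC1-like intracellular cholesterol transporter 1 (Homo sapiens) (a higher number here means a weaker inhibitor, a lower number a stronger inhibitor), compound 3 gives 2500 nM, compound 1 gives 4400 nM and compound 2 gives 22000 nM, the highest of the three numbers; the gaps from compound 2 to compound 1 and to compound 3 both lie beyond the usual scatter. Compound 4 `CCC1CCCN(C(=O)CN2CN(c3ccccc3)C3(CCN(C(=O)c4ccc(C(C)(C)C)cc4)CC3)C2=O)C1` is not yet measured. It differs from compound 2 on a carbonyl carbon whose other neighbours are a saturated chain carbon: 3-ethylpiperidin-1-yl in place of piperazin-1-yl on a carbonyl carbon. Among the compounds with values here, no step between two measured compounds isolates this change. Compounds 1 and 3 carry other groups on the corresponding carbonyl carbon and give lower numbers than compound 2, but they also differ from compound 2 elsewhere, so they offer only a loose guide. In this assay the expected step of a 5.5-fold lower number from compound 2 to compound 4 (0.74 log units; beyond the scatter) is toward a lower number, moderate in size and not certain to clear the scatter. Compound 4 is estimated at 4000 nM, with a range from 1200 nM to 13000 nM.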

Compound 4, half-maximal inhibitory concentration: 3900 nM
For compound 4 the middle estimate is 1.0-fold (0.01 log units) above the measured one; measured number inside the range.
By their numbers in this assay, from the lowest: compounds 3, 4 and 1 (each within the scatter of the next); then compound 2.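

In this assay, within the data shown here, 3-ethylpiperidin-1-yl in place of piperazin-1-yl on a carbonyl carbon gives a 5.6-fold lower number from compound 2 to compound 4 (0.75 log units; beyond the scatter) and is the only step here that isolates this position. The number at this position therefore responds to the group it carries, with the rest of compound 2 unchanged, and the lower number comes with a ring that has no hydrogen-bond donor or acceptor. No measurement here accounts for the step.

The step does not separate the added ethyl from the replaced ring nitrogen, and piperidin-1-yl or morpholin-4-yl on the same carbonyl carbon would tell these apart. Also open, on these data alone, is whether a longer chain on the ring, or a carboxylic acid there, keeps the lower number.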